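The source may report more compounds than this note shows. Statements on the series, on what has been measured and on what is new or still open speak of the compounds shown alone.

Compound 1 `CCC(=O)Nc1cc(C(=O)Nc2ccc(C)cc2)ccc1OC` in an ADME assay on MDCK cells (Canis lupus familiaris) for cytotoxicity, read by cytopathic effect, with a stated time of 48 h; on this read-out lower numbers stand for higher toxicity in this test and higher numbers for lower toxicity in this test: 162 uM
Compound 2 `CCC(=O)Nc1cc(C(=O)NC2CCCCC2)ccc1OC` in this assay: 510 uM
Compound 3 `COc1ccc(C(=O)Nc2ccccc2)cc1NC(C)=O` in this assay: > 703 uM

Three compounds share a core carrying a methoxy group and an amide, and all were run in this assay, which asks at what concentration the cells begin to suffer. Compound 1 gives 162 uM. Compound 2 gives 510 uM. Within the data shown here, the only pair that differs in a single place is compound 1 against compound 2, and there the change is a 3.1-fold higher number from compound 1 to compound 2 (0.50 log units; beyond the scatter). Compound 3 does not yield a number at all, only a limit of the assay, > 703 uM. Compound 3 therefore sits at the limit of > 703 uM in this assay, at which 1 of the 3 values shown sits, which places it among the least harmful compounds seen here.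

Compound 4 `CCC(=O)Oc1cc(C(=O)Nc2ccccc2)ccc1OC` has not been measured. It differs from compound 3 by propanoyloxy in place of acetamido on an aromatic carbon. Among the measured compounds shown here, no measured step touches this position: the one step known, a 3.1-fold higher number from compound 1 to compound 2 (0.50 log units; beyond the scatter), concerns the group on the amide-type nitrogen, so it offers no direct guide. For the measured compounds named here, the one measured change elsewhere on the core gives a 3.1-fold higher number from compound 1 to compound 2 (0.50 log units; beyond the scatter). For compound 4 a value of 500 uM is expected, within 150 uM to 1500 uM. The expected step is an at least 1.4-fold lower number from compound 3 to compound 4 (0.14 log units; that floor lies within the scatter), which is no change beyond the scatter.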

Compound 4, half-maximal toxic concentration: 519 uM
Estimate against measurement, compound 4: 1.0-fold (0.02 log units) below; low and high end bracket the measured number.
By their numbers in this assay, from the lowest: compound 1; then compounds 2 and 4 (each within the scatter of the next). At a limit, above all of these: compound 3.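

Among these compounds, at the aromatic carbon ortho to a methoxy group, the earlier compounds showed no step at all, and this swap of acetamido for propanoyloxy gives an at least 1.3-fold lower number from compound 3 to compound 4 (0.13 log units; that floor lies within the scatter) in this assay. This one change alters several things at once, since the link to the core goes from nitrogen to oxygen, the chain grows, and the hydrogen-bond donor of acetamido is lost, yet the printed floor of the step shows no change beyond the scatter. Compound 3 has only a limit of the assay, > 703 uM, so its true value is unknown, and the real step could be larger than that floor because the starting point is not a number: the limit of > 703 uM in this assay, at which 1 of the 4 values shown sits.

The compounds shown do not separate the effect of the linking atom from that of chain length, which a butanoyloxy group or a pair such as acetoxy against acetamido on the same core could begin to address. They also leave open how a free amine or a hydroxyl group on this same aromatic carbon would read in this assay.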